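The compounds below may be only part of what the source reports. "The series", "measured", "known", "first", "only" and "open" are said of these compounds alone.

Going by the values given here, compound 2, `COc1ccc(C(=O)Nc2cccc(-c3oc4cc(-c5ccc(F)cc5)ccc4c(=O)c3O)c2)c(F)c1`, is one of two compounds measured in a functional assay on MCF7 cells (Homo sapiens) for antiproliferative activity, read by CCK-8 assay, with a stated time of 72 h; on this read-out lower numbers stand for stronger inhibition and higher numbers for weaker inhibition. In this assay compound 2 gives 20000 nM, the highest of the two numbers shown. Its neighbour compound 1, `O=C(Nc1cccc(-c2oc3cc(-c4ccc(F)cc4)ccc3c(=O)c2O)c1)c1ccc(Cl)cc1`, gives 4730 nM in this assay, and the step of a 4.2-fold higher number from compound 1 to compound 2 (0.63 log units; beyond the scatter) separates the two.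

Compound 3, `O=C(Nc1cccc(-c2oc3cc(-c4ccc(F)cc4)ccc3c(=O)c2O)c1)c1cc(F)cc(F)c1`, has not been measured. It differs from compound 2 by 3,5-difluorophenyl in place of 2-fluoro-4-methoxyphenyl on a carbonyl carbon. Among the compounds with values here, no measured step covers this exact exchange. Within the data shown here, the only step that bears on it is a 4.2-fold higher number from compound 1 to compound 2 (0.63 log units; beyond the scatter), which shows that exchanging the aryl group on this carbonyl carbon moved the number by a modest amount, beyond the scatter. Compound 3, like compound 1, carries a phenyl ring without a hydrogen-bond acceptor on that carbonyl carbon, while compound 2 carries one acceptor there. The account therefore expects a modest move back toward the number of compound 1, as the step of a 2.5-fold lower number from compound 2 to compound 3 (0.40 log units; beyond the scatter). Compound 3 is estimated in this assay at 8000 nM, with a range from 3000 nM to 25000 nM.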

Compound 3, half-maximal inhibitory concentration: 2490 nM
Compound 3: the middle estimate sits 3.2-fold (0.51 log units) above what was measured, outside the stated range (below it).
By their numbers in this assay, from the lowest: compounds 3 and 1 (each within the scatter of the next); then compound 2.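

In this assay, going by these compounds alone, the new compound gives an 8.0-fold lower number from compound 2 to compound 3 (0.90 log units; beyond the scatter) and so sets compound 2 apart from a second neighbour, which the single earlier step could not do. The other new step, a 1.9-fold lower number from compound 1 to compound 3 (0.28 log units; within the scatter), keeps the 4-chlorophenyl and 3,5-difluorophenyl groups together on this carbonyl carbon, so among these three amides it is the 2-fluoro-4-methoxyphenyl group alone that stands apart, and the two different halogen patterns read alike. Nothing measured here offers an explanation for this split.

The compounds shown do not separate the methoxy group from the fluorine within the 2-fluoro-4-methoxyphenyl group, and a plain phenyl, a 4-methoxyphenyl or a 2-fluorophenyl on the same carbonyl carbon would be needed to tell which of the two goes with the higher number. They also leave open how an amine or a carboxylic acid on this aryl ring would read, and whether a pyridine ring in place of the phenyl ring would keep the number of compound 3.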